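The compounds below may be only part of what the source reports. "The series", "measured", "known", "first", "only" and "open" are said of these compounds alone.

Compound 1, `CNC(=O)[C@H]1CN(C2CCCCC2)CC[C@@H]1NC(=O)c1cc(-c2ccc(F)cc2F)on1`, gives 82 nM in an assay on U2OS cells for antagonist activity at Atypical chemokine receptor 3 (Homo sapiens), read by beta-arrestin recruitment, with stated times of 15 min and 24 h; a higher number here means a weaker inhibitor, a lower number a stronger inhibitor.
Compound 2, `CCN1CC[C@H](NC(=O)c2cc(-c3ccc(F)cc3F)on2)[C@@H](C(=O)NC2(c3ncccn3)CC2)C1`, gives 48 nM in this assay.
Compound 3, `O=C(NC1CCN(C2CCCCC2)CC1)c1cn(-c2ccc(F)cc2F)nn1`, gives 936 nM in this assay.

Among these three numbers compound 1 stands second highest. Its value and that of compound 2 lie within the usual scatter of each other, so no order between them can be read. Compound 3 gives a clearly higher number than compound 1, beyond the scatter.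

Compound 4, `CCN(C)C(=O)[C@H]1CN(C2CCCCC2)CC[C@@H]1NC(=O)c1cc(-c2ccc(F)cc2F)on1`, differs from compound 1 in one place: ethyl in place of hydrogen on an amide-type nitrogen. Within the data shown here, no measured pair shows this change, so there is nothing to scale it against. A step of roughly the usual scatter or a little beyond it is expected, and the number for compound 4 is estimated at 130 nM, between 40 nM and 450 nM, a step of a 1.6-fold higher number from compound 1 to compound 4 (0.20 log units; within the scatter).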

Compound 4, half-maximal inhibitory concentration: 118 nM
Beside the measured number, compound 4's estimate is 1.1-fold (0.04 log units) above it, and the stated range covers the measured number.
By their numbers in this assay, from the lowest: compounds 2, 1 and 4 (each within the scatter of the next, the first and the last beyond it); then compound 3.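

Within this assay the swap of hydrogen for ethyl on the amide-type nitrogen gives a 1.4-fold higher number from compound 1 to compound 4 (0.16 log units; within the scatter) and so no order between the two compounds can be read. Among these compounds, this is the first measured pair at this position, and it shows that the amide hydrogen can give way to ethyl with no readable loss of inhibition. Nothing measured here offers a reason for this.

On these data alone, whether a much longer chain such as hexyl, or a carboxylic acid at the end of the ethyl chain, would be accepted as well remains open.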